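This account rests on a few compounds, and the source may have more. Where it says the series, first, only, none or still open, it means among the compounds named here.

Measured so far in an assay (strain Wistar) for inhibition of Hormone-sensitive lipase (Rattus norvegicus), read by spectrophotometry; a lower number here means a stronger inhibitor, a higher number a weaker inhibitor:
compound 1 `Cc1c(C(C)C)c(=O)on1C(=O)N1CCCCC1` gives 2 nM
compound 2 `Cc1c(C(C)C)c(=O)on1C(=O)N1CCC(c2ccccc2)CC1` gives 12 nM
compound 3 `Cc1c(C(C)C)c(=O)on1C(=O)N1CCC(c2ccc(C(F)(F)F)cc2)CC1` gives 160 nM

Compound 2 stands second highest of the three numbers. Both steps that touch it lie beyond the scatter: a 6.0-fold higher number from compound 1 to compound 2 (0.78 log units; beyond the scatter) and a 13-fold higher number from compound 2 to compound 3 (1.12 log units; beyond the scatter). Read together, placing a group on the saturated ring carbon of compound 1 costs a modest amount, and enlarging that group with trifluoromethyl costs a large amount more.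

Compound 4 `Cc1c(C(C)C)c(=O)on1C(=O)N1CCC(C(=O)N(C)C)CC1` is compound 2 with dimethylcarbamoyl in place of phenyl on a saturated ring carbon. The two measured steps bear on this only indirectly: they show that the saturated ring carbon tolerates a substituent at some cost, and that more substitution there costs more. Within the data shown here, no measured pair shows a group without a ring at this position, so the direction is open. With the entering group having no ring, and compound 1 sitting at 2 nM with nothing on that carbon, the expectation is a number between compound 1 and compound 2, or close to compound 2.

For compound 4 in this assay the estimate is 8 nM, range 2 nM to 40 nM. The expected step is a 1.5-fold lower number from compound 2 to compound 4 (0.18 log units; within the scatter), not beyond the scatter.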

Compound 4, half-maximal inhibitory concentration: > 1000 nM
Compound 4: only a limit was reported (the forecaster's own chance of this, stated with the estimate: 2%); middle value at least 120-fold (2.09 log units) away from the limit.
By their numbers in this assay, from the lowest: compound 1; then compound 2; then compound 3. At a limit, above all of these: compound 4.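

In this assay the value of compound 4 is a limit and not a number: the limit of > 1000 nM in this assay, at which 1 of the 4 values shown sits.

Even so, replacing phenyl with dimethylcarbamoyl on the saturated ring carbon gives an at least 83-fold higher number from compound 2 to compound 4 (1.92 log units; beyond the scatter), and the comparison with the unsubstituted carbon gives an at least 500-fold higher number from compound 1 to compound 4 (2.69 log units; beyond the scatter). The earlier compounds shown here left open how a group without a ring would fare at this position; here dimethylcarbamoyl, with fewer heavy atoms than phenyl, no ring and one hydrogen-bond acceptor, gives a much higher number, so among compound 1, compound 2 and compound 4 the number does not simply follow the heavy-atom count of the substituent, and compound 4 is the one that goes against that order.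

A single compound cannot separate the loss of the aromatic ring from the entry of the carbonyl, so which of the two matters remains unresolved. Also open, on these data alone, are how a plain alkyl chain, a hydroxymethyl group, an amine or a carboxylic acid on the same carbon would compare, and how large the step to compound 4 really is.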